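A few compounds are considered here, and "the series" means these few. Any claim that something is new, unique, unknown or untested is made for them only; others in the source may bear on it.

Values measured in a functional assay on HL-60 cells (Homo sapiens) for inhibition, read by XTT assay, with a stated time of 72 h (a higher number here means a weaker inhibitor, a lower number a stronger inhibitor), follow for three compounds.

compound 1 `[N-]=[N+]=NCc1ncnc2c1ncn2[C@@H]1O[C@H](CO)[C@@H](O)[C@H]1O` gives 780 nM
compound 2 `CN(Cc1ncnc2c1ncn2[C@@H]1O[C@H](CO)[C@@H](O)[C@H]1O)c1ccccc1` gives 3400 nM
compound 3 `OC[C@H]1O[C@@H](n2cnc3c(Cn4ccc5ccccc54)ncnc32)[C@H](O)[C@@H]1O` gives 9100 nM

Going by the values given here, of these three numbers, the one for compound 2 (3400 nM) is second highest. Compound 4 (`OC[C@H]1O[C@@H](n2cnc3c(CSCc4ccccc4)ncnc32)[C@H](O)[C@@H]1O`) has benzylsulfanyl in place of methyl(phenyl)amino on a saturated chain carbon bound to an aromatic carbon. Both groups hold one six-membered aromatic ring of carbon only. The closest guide is the modest 2.7-fold higher number from compound 2 to compound 3 (0.43 log units; beyond the scatter), which also swaps one ring-bearing group for another. The larger steps, a 4.4-fold higher number from compound 1 to compound 2 (0.64 log units; beyond the scatter) and a 12-fold higher number from compound 1 to compound 3 (1.07 log units; beyond the scatter), both start from azido, which plays no part here. The expected step is small and of uncertain direction, estimated as a 1.2-fold higher number from compound 2 to compound 4 (0.07 log units; within the scatter) overall. In this assay the estimated value for compound 4 is 4000 nM, with an expected range from 1300 nM to 12000 nM overall.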

Compound 4, half-maximal inhibitory concentration: 19200 nM
For compound 4 the middle estimate is 4.8-fold (0.68 log units) below the measured one, outside the stated range (above it).
By their numbers in this assay, from the lowest: compound 1; then compound 2; then compound 3; then compound 4.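

In this assay, benzylsulfanyl and methyl(phenyl)amino have the same heavy-atom count and each hold one aromatic ring of carbon, yet the swap gives a 5.6-fold higher number from compound 2 to compound 4 (0.75 log units; beyond the scatter) on this chain carbon, so those shared counts do not settle the outcome here. Benzylsulfanyl also trails the other two groups, with a 2.1-fold higher number from compound 3 to compound 4 (0.32 log units; beyond the scatter) and a 25-fold higher number from compound 1 to compound 4 (1.39 log units; beyond the scatter) in turn, which makes compound 4 the weakest inhibitor of the four.

The compounds shown leave open how a simple amine or a methoxy group at this place would compare with azido. No measurement at hand explains the gaps between these groups.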